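This account rests on a few compounds, and the source may have more. Where it says the series, first, only, none or still open, it means among the compounds named here.

Measured so far:
compound 1, `COc1cccc(OC)c1OCCNCCOc1ccccc1OCc1cccc(Cl)c1`, 7.93
compound 2, `COc1cccc(OC)c1OCCNCCOc1ccccc1OCc1ccccc1C`, 7.67

Two compounds of this series carry a number in a functional assay on spleen for antagonist activity at Alpha-1B adrenergic receptor (Rattus norvegicus); on this read-out higher numbers stand for higher potency (the scale is a negative logarithm) and lower numbers for lower potency. Going by the values given here, compound 2 stands next to compound 1, the only other measured member; the gap between them, a number 0.26 log units lower from compound 1 to compound 2 (within the scatter), is within the scatter, so the two numbers cannot be told apart.

The compound to be measured next is compound 3, `COc1ccccc1COc1ccccc1OCCNCCOc1c(OC)cccc1OC`. It differs from compound 2 by methoxy in place of methyl on an aromatic carbon. Among the compounds with values here, the one measured step, from compound 1 to compound 2, also changed the group on this same ring, swapping 3-chlorophenyl for 2-methylphenyl, and that step was a number 0.26 log units lower from compound 1 to compound 2 (within the scatter), within the scatter. Within the data shown here, no measured step exchanges methyl for methoxy, so that step stands alone; the only comparison available shows a change of substituent on this ring leaving the number in this assay essentially where it was.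

On that basis the step to compound 3 is expected to stay within the scatter, estimated as a number 0.03 log units higher from compound 2 to compound 3 (within the scatter). Compound 3 is therefore estimated at 7.7 in this assay, with a range from 7.2 to 8.2.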

Compound 3, negative logarithm of the antagonist equilibrium constant: 8.13
Beside the measured number, compound 3's estimate is 0.43 log units below it; the measured number falls inside the stated range.
By their numbers in this assay, from the lowest: compounds 2, 1 and 3 (each within the scatter of the next, the first and the last beyond it).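

Going by these compounds alone, at the aromatic carbon ortho to a large group, the exchange of methyl for methoxy gives the first step beyond the scatter in this assay: a number 0.46 log units higher from compound 2 to compound 3 (beyond the scatter). The step is modest, but it shows that this place can respond to a small change of group, which the earlier pair could not show. Against 3-chlorophenyl the picture differs, since a number 0.20 log units higher from compound 1 to compound 3 (within the scatter) leaves 2-methoxyphenyl and 3-chlorophenyl indistinguishable on this read-out, and only the pair of 2-methylphenyl and 2-methoxyphenyl is separated. Nothing available accounts for the difference between methyl and methoxy at this place.

Still open, on these data alone, is whether a hydroxyl, an ethoxy or an amino group at the same place would follow methoxy or fall back towards methyl, since the result rests on a single pair of compounds. Also open, as far as these compounds go, is how these compounds compare at other adrenergic receptor subtypes, so nothing here can be said about selectivity.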